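The source may hold more compounds than are shown below. What is called first, only, known or untested is meant among the compounds shown, and "the series" means these compounds.

Compound 1: `Fc1ccc2nc(-c3cc(-c4ccccc4)nn3-c3ccccc3)ccc2c1` gives 98.3%
Compound 2: `COc1ccc(-c2cc(-c3ccc4cc(F)ccc4n3)n(-c3ccccc3)n2)cc1` gives 98.9%

In an ADME assay on Huh-7 cells (Homo sapiens) for cytotoxicity, read by XTT assay, with a stated time of 3 days, tested at 200 uM (a higher number here means a weaker effect of the compound at the concentration tested, a lower number a stronger effect), compound 1 gives 98.3%, and compound 2 gives 98.9%; the two values lie within the usual scatter of each other. Compound 3, `Fc1ccc(-n2nc(-c3ccccc3)cc2-c2ccc3cc(F)ccc3n2)cc1`, has not yet been measured. It differs from compound 1 by fluoro in place of hydrogen on an aromatic carbon. Among the compounds with values here, the only measured step, a number 0.6 percentage points higher from compound 1 to compound 2 (within the scatter), concerns a different change and stays within the scatter, so it offers no sign of a shift. The expected step is a number 0.3 percentage points lower from compound 1 to compound 3 (within the scatter), within the scatter. Compound 3 is therefore estimated at 98%, between 88% and 102%.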

Compound 3, a percentage reported as activity, at one concentration (the size of the read-out at that concentration, not a potency): 91.6%
For compound 3 the middle estimate is 6.4 percentage points above the measured one; the measured number falls inside the stated range.
By their numbers in this assay, from the lowest: compounds 3, 1 and 2 (each within the scatter of the next).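

Replacing phenyl with 4-fluorophenyl, with the fluoro para to a large group, gives a number 6.7 percentage points lower from compound 1 to compound 3 (within the scatter) in this assay, so this single atom produces no change that can be separated from ordinary assay variation. Within the data shown here, this is the first view of a change at this position, and the fluoro is tolerated here without a clear shift in the read-out. Nothing measured here bears on why the number falls where it does. Still open, from the compounds shown here alone, is whether an amine or a carboxylic acid on this same carbon would move the value beyond the scatter.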